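The compounds below may be only part of what the source reports. "The series", "measured", "known", "first", "only" and "open" are said of these compounds alone.

Series notes, step from compound 2 to compound 3.

Of the compounds shown here, two have been measured in an assay on cells (Hepatocyte) for inhibition of glucokinase regulatory protein (Mus musculus), with stated times of 20 min and 40 min; a lower number here means that less compound is needed, a higher number that more compound is needed for the effect. Compound 1 `CC#C[C@H]1CN(S(=O)(=O)c2ccc(N)nc2)CCN1c1ccc(S(=O)(=O)Nc2ccccc2)cc1` carries a phenylsulfonamide on the aromatic ring attached to the core. In this assay compound 1 gives only a limit of the assay, > 12500 nM, and no number (the limit of > 12500 nM in this assay, at which 1 of the 2 values shown sits). Compound 2 `CC#C[C@H]1CN(S(=O)(=O)c2ccc(N)nc2)CCN1c1ccc(S(C)(=N)=O)cc1` carries a methylsulfoximine in that position instead. In this assay compound 2 gives 704 nM. The step is an at least 17-fold lower number from compound 1 to compound 2 (1.24 log units; beyond the scatter). Compound 2 therefore holds the only actual number shown in this assay; the other entry is a limit.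

Compound 3 `CC#C[C@H]1CN(S(=O)(=O)c2ccc(N)nc2)CCN1c1ccc([C@](O)(CO)C(F)(F)F)cc1` changes the same position again: a group of 8 heavy atoms (3 carbon, 2 oxygen, 3 fluorine; no ring) in place of a group of 4 heavy atoms (1 carbon, 1 nitrogen, 1 oxygen, 1 sulfur; no ring), on an aromatic carbon. Going by the values given here, only the step from compound 1 to compound 2 bears on this change, and it shows that exchanging the group on this aromatic carbon can move this assay by a large amount. That step does not tell in which direction a diol in place of the sulfoximine will move, so a moderate change in either direction is within what is expected here. Compound 3 is expected to give roughly 350 nM, in the range 60 nM to 2000 nM, which would mean an estimated step of a 2.0-fold lower number from compound 2 to compound 3 (0.30 log units; within the scatter).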

Compound 3, half-maximal effective concentration: 98 nM
For compound 3 the middle estimate is 3.6-fold (0.55 log units) above the measured one, and the stated range covers the measured number.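

In this assay, the exchange on this aromatic carbon, para to a large group, now has a direction for a group without a ring: 1,2-dihydroxy-1-(trifluoromethyl)ethyl in place of the methylsulfoximine gives a 7.2-fold lower number from compound 2 to compound 3 (0.86 log units; beyond the scatter). The step from the phenylsulfamoyl group to the same diol is wider still, an at least 120-fold lower number from compound 1 to compound 3 (2.10 log units; beyond the scatter), so among the three compounds shown, the position spans a large range with the core unchanged. Compound 1 stands at a limit of the assay and not at a number, so that step fixes only a minimum size and not an exact one: the limit of > 12500 nM in this assay, at which 1 of the 3 values shown sits.

The compounds shown leave open which part of the new group goes with the lower number: the trifluoromethyl and the two hydroxyl groups appear only together, and the opposite configuration at the defined stereocentre is not among them. From the compounds shown here alone, it also stays open whether a simple hydroxymethyl, a carboxylic acid or an amine on this aromatic carbon would give a number close to that of compound 3.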